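Anilinomethyl-imidazoline series: methyl to chloro at the ring

This account rests on a few compounds, and the source may have more. Where it says the series, first, only, none or still open, it means among the compounds named here.

Measured so far:
compound 1 `CSc1ccc(C)cc1NCC1=NCCN1`, 96%
compound 2 `Cc1ccc(S(C)(=O)=O)c(NCC2=NCCN2)c1`, 91%
compound 3 `COc1ccc(SC)c(NCC2=NCCN2)c1`, 92%

In a functional assay for agonist activity at Alpha-1B adrenergic receptor (Homo sapiens) (on this read-out higher numbers stand for larger maximal responses and lower numbers for smaller maximal responses), compound 1 reaches 96%. The step of a number 5 percentage points lower from compound 1 to compound 2 (within the scatter) leaves compound 2 at 91%, and compound 3 gives 92%, so compound 2 sits within the scatter of both other compounds; no order among the three can be read from these numbers.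

Compound 4 `CS(=O)(=O)c1ccc(Cl)cc1NCC1=NCCN1` is not yet measured. Relative to compound 2 the change is chloro in place of methyl on an aromatic carbon. Among the compounds with values here, no measured step exchanges methyl for chloro. The two steps that exist, a number 5 percentage points lower from compound 1 to compound 2 (within the scatter) and a number 4 percentage points lower from compound 1 to compound 3 (within the scatter), each alter one ring substituent and each stays within the scatter. On that basis the expected step of a number 1 percentage points lower from compound 2 to compound 4 (within the scatter) for compound 4 is none beyond the scatter. Compound 4 is therefore estimated at 90% in this assay, with a range from 75% to 102%.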

Compound 4, largest response reached (reported as maximum), in percent of the reference or control that the assay uses: 103%
Estimate against measurement, compound 4: 13 percentage points below; measured number above the stated range.
By their numbers in this assay, from the lowest: compounds 2, 3, 1 and 4 (each within the scatter of the next, the first and the last beyond it).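

In this assay, within the data shown here, chloro in place of methyl on the aromatic carbon para to the methylsulfonyl group gives a number 12 percentage points higher from compound 2 to compound 4 (beyond the scatter), the only step so far that lies beyond the scatter. The same ring carbon had shown no clear response when methoxy replaced methyl with methylsulfanyl in place of methylsulfonyl, in a number 4 percentage points lower from compound 1 to compound 3 (within the scatter), so the position is not indifferent to its substituent, although the two exchanges stand on different parents and cannot be set directly against each other. No data here account for the step.

As far as these compounds go, it remains open whether chloro gives a similar step on the methylsulfanyl parent. From the compounds shown here alone, the response to bromo, trifluoromethyl or an amine on this carbon also remains open.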